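This account rests on a few compounds, and the source may have more. Where it says the series, first, only, none or still open, it means among the compounds named here.

Values in a functional assay on HepG2 cells (Homo sapiens) for cytotoxicity, read by MTT assay, with a stated time of 48 h; on this read-out lower numbers stand for stronger inhibition and higher numbers for weaker inhibition:
- compound 1 `CC1=NN(C(=O)c2ccc([N+](=O)[O-])cc2)C(c2ccccc2O)C1`: 30100 nM
- compound 2 `CC1=NN(C(=O)c2ccc(C)cc2)C(c2ccccc2O)C1`: 11300 nM
- compound 3 `CC1=NN(C(=O)CCc2ccccc2)C(c2cc(Br)ccc2O)C1`: 17900 nM

Compound 2, at 11300 nM, has the lowest of the three numbers, but compound 3, at 17900 nM, lies within the scatter of it. Only compound 1 stands clearly apart from compound 2.

The next compound is compound 4 `CC1=NN(C(=O)CN2CCCCC2)C(c2ccccc2O)C1`, which carries (piperidin-1-yl)methyl in place of 4-methylphenyl on a carbonyl carbon.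

Within the data shown here, only one measured step is available, a 2.7-fold lower number from compound 1 to compound 2 (0.43 log units; beyond the scatter). It is modest and comes from a methyl-for-nitro swap on an aromatic carbon, so it bears on this change only indirectly. Among the measured compounds shown here, no measured step replaces the whole group on the carbonyl carbon, so the size of this change remains untested. For the measured compounds named here, the three values so far stay close together, and compound 1 at 30100 nM marks the top of that band. No step beyond the scatter is therefore expected, only a slight rise at most.

The expected change is a 1.6-fold higher number from compound 2 to compound 4 (0.20 log units; within the scatter).

For compound 4 the estimated value is 18000 nM, with an expected range of 7000 nM to 50000 nM.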

Compound 4, half-maximal inhibitory concentration: 3020 nM
For compound 4 the middle estimate is 6.0-fold (0.78 log units) above the measured one; measured number outside the range, below it.
By their numbers in this assay, from the lowest: compound 4; then compounds 2, 3 and 1 (each within the scatter of the next, the first and the last beyond it).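

In this assay, among these compounds, replacing the whole group on the carbonyl carbon gives a 3.7-fold lower number from compound 2 to compound 4 (0.57 log units; beyond the scatter), the first measured exchange of that group. This position therefore accepts (piperidin-1-yl)methyl, with a non-aromatic ring containing a hetero atom, in place of 4-methylphenyl and its aromatic carbon ring, and the number falls beyond the scatter, which the earlier swap on an aromatic carbon could not show. No measured information accounts for this drop.

In this pair, loss of the aromatic ring and entry of the ring nitrogen occur together, so their separate contributions remain unresolved. Also open, as far as these compounds go, is how the series would respond to morpholine in place of piperidine, to a dimethylamino group, or to a longer chain carrying the piperidine.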